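Swapping isopropyl for methyl in a weak antiproliferative pair

This account rests on a few compounds, and the source may have more. Where it says the series, first, only, none or still open, it means among the compounds named here.

Compound 1 `Cc1cc(=O)n2nc(SCc3ccc(F)cc3)nc2[nH]1`: > 80000 nM (a limit)
Compound 2 `Cc1cc(=O)n2nc(SCc3ccc(C(C)C)cc3)nc2[nH]1`: 35200 nM

Among the compounds with values here, in a functional assay on A549 cells (Homo sapiens) for antiproliferative activity, read by MTT assay, with a stated time of 24 h (a lower number here means a stronger inhibitor, a higher number a weaker inhibitor), compound 2 gives 35200 nM, the only actual number so far. Compound 1 gives > 80000 nM, which is a limit of the assay and not a number.

The next compound, compound 3 `Cc1ccc(CSc2nc3[nH]c(C)cc(=O)n3n2)cc1`, carries methyl in place of isopropyl on an aromatic carbon. Within the data shown here, one measured step bears on this change, and it is also at this group: an at least 2.2-fold lower number from compound 1 to compound 2 (0.35 log units; beyond the scatter), with isopropyl in place of fluoro. Among the measured compounds shown here, with only this step to go on, removing the isopropyl is expected to give up some or all of that gain. A modest move towards a higher number is therefore expected in this assay, and a reading at the limit is possible. The expected step is a 1.7-fold higher number from compound 2 to compound 3 (0.23 log units; within the scatter). For compound 3 the estimated value is 60000 nM, with an expected range of 28000 nM to 120000 nM.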

Compound 3, half-maximal inhibitory concentration: 50100 nM
Beside the measured number, compound 3's estimate is 1.2-fold (0.08 log units) above it; low and high end bracket the measured number.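

In this assay, methyl in place of isopropyl gives a 1.4-fold higher number from compound 2 to compound 3 (0.15 log units; within the scatter), so the size of this alkyl group makes no readable difference between these two compounds. Methyl in place of fluoro gives an at least 1.5-fold lower number from compound 1 to compound 3 (0.20 log units; that floor lies within the scatter), and that floor alone does not separate compound 3 from compound 1, although compound 2 does clear the scatter against compound 1. The true distance to compound 1 cannot be stated, because its reading is a limit and not a number: the limit of > 80000 nM in this assay, at which 1 of the 3 values shown sits.

From the compounds shown here alone, whether a group of another kind at this position, such as an amine, a carboxylic acid or a longer chain, would move the number beyond the scatter remains open. Going by these compounds, all three compounds share the same core, so the effect of a change elsewhere on it also stays open.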